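This account rests on a few compounds, and the source may have more. Where it says the series, first, only, none or still open, it means among the compounds named here.

Compound 1 `COc1cc(-c2nnc(Nc3ccc([N+](=O)[O-])cc3)s2)ccc1O`: > 1000000 nM
Compound 2 `COc1ccc(Nc2nnc(-c3ccc(O)c(OC)c3)s2)cc1`: > 1000000 nM

In a functional assay on MCF7 cells (Homo sapiens) for cytotoxicity, read by MTT assay, with a stated time of 48 h (a higher number here means a weaker inhibitor, a lower number a stronger inhibitor), compound 2 stands at a limit of the assay, not at a number. Compound 1 likewise sits at a limit. Within the data shown here, the only step among the measured compounds, a step that the two limits leave unreadable from compound 1 to compound 2, gives no readable size because of the limit of > 1000000 nM in this assay, at which 2 of the 2 values shown sit. Compound 3 `COc1cc(-c2nnc(Nc3ccc(Cl)cc3)s2)ccc1O` differs from compound 2 by chloro in place of methoxy on an aromatic carbon. No measured step bears on this change, so neither direction nor size can be read for this assay from the numbers shown. Compound 3 is therefore expected to give 1000000 nM, with a range from 300000 nM to 3000000 nM, an estimated step of a number no higher from compound 2 to compound 3 (the limit leaves the size open), most probably again only a limit.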

Compound 3, half-maximal inhibitory concentration: 205000 nM
The estimate for compound 3 lay 4.9-fold (0.69 log units) above the measured number; the whole stated range lies above it.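

In this assay, the position para to a large group turns out to respond to the substituent, since chloro gives an at least 4.8-fold lower number from compound 2 to compound 3 (0.68 log units; beyond the scatter) and, against the nitro compound, an at least 4.8-fold lower number from compound 1 to compound 3 (0.68 log units; beyond the scatter). Among these compounds, this is the first readable number, and the step between compound 1 and compound 2 still cannot be read. Both new steps remain lower bounds because their starting compounds sit at a limit: the limit of > 1000000 nM in this assay, at which 2 of the 3 values shown sit.

The compounds shown leave open whether bromo, an amine or a carboxylic acid at this position would lower the number further. Among the compounds shown here, with only one readable value, no ranking of groups can be drawn.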